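Cytotoxicity of triazole analogues bearing aryl groups on nitrogen

The source may report more compounds than this note shows. Statements on the series, on what has been measured and on what is new or still open speak of the compounds shown alone.

Measured compounds:
compound 1 `CC(C)c1ccc(-n2nc(-c3ccc(C(F)(F)F)cc3O)nc2-c2ccccc2O)cc1`: 108%
compound 2 `Oc1cc(C(F)(F)F)ccc1-c1nc(-c2ccccc2O)n(-c2ccc(Cl)cc2)n1`: 96.1%
compound 3 `Cc1ccc(-n2nc(-c3ccc(C(F)(F)F)cc3O)nc2-c2ccccc2O)c(C)c1`: 106%

In a functional assay on PC-12 cells (Rattus norvegicus) for cytotoxicity, read by MTT assay, with stated times of 2 h and 24 h, tested at 10 uM (on this read-out lower numbers stand for a weaker effect and higher numbers for a stronger effect at the one concentration tested), compound 1 gives 108%, the highest of the three numbers. Compound 3 stands close to it, with a number 2 percentage points lower from compound 1 to compound 3 (within the scatter), while compound 2 lies further away, with a number 11.9 percentage points lower from compound 1 to compound 2 (beyond the scatter). Between compound 2 and compound 3 there is a number 9.9 percentage points higher from compound 2 to compound 3 (within the scatter).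

Compound 4 `Cc1cc(C)cc(-n2nc(-c3ccc(C(F)(F)F)cc3O)nc2-c2ccccc2O)c1` has not yet been measured in this assay. It differs from compound 1 in one place: 3,5-dimethylphenyl in place of 4-isopropylphenyl on an aromatic nitrogen. Among the measured compounds shown here, the step that bears most directly on it is the one from compound 1 to compound 3, where a 2,4-dimethylphenyl group replaced the 4-isopropylphenyl group and the read-out moved only a number 2 percentage points lower from compound 1 to compound 3 (within the scatter). The step to the chloro compound, compound 2, was larger, but that change is not the one made here. Compound 4 is therefore expected to show no step beyond the scatter, a number 3 percentage points lower from compound 1 to compound 4 (within the scatter). The estimate for compound 4 in this assay is 105%, in the range 92% to 118%.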

Compound 4, a percentage reported as activity, at one concentration (the size of the read-out at that concentration, not a potency): 105%
For compound 4 middle estimate and measured number coincide at the digits printed, within the range that was stated.
By their numbers in this assay, from the lowest: compounds 2, 4, 3 and 1 (each within the scatter of the next, the first and the last beyond it).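

On the aromatic nitrogen, 3,5-dimethylphenyl could not be told apart from either 4-isopropylphenyl, a number 3 percentage points lower from compound 1 to compound 4 (within the scatter), or 2,4-dimethylphenyl, a number 1 percentage points lower from compound 3 to compound 4 (within the scatter), so this assay does not separate these three aryl groups, even with the two methyl groups arranged differently. Against 4-chlorophenyl the result is a number 8.9 percentage points higher from compound 2 to compound 4 (within the scatter), which places compound 4, like compound 3, within the scatter of compound 2 and leaves the step between compound 1 and compound 2 as the only one beyond it. Nothing available offers an explanation for these readings.

The compounds shown leave open whether a phenyl group carrying an amine or a carboxylic acid would stay in this range in this assay. They also leave open how a longer alkyl chain on this nitrogen, in place of the aryl group, would read.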